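Thiophen-2-yl replaces 2,3-difluorophenyl: notes on compound 4

This account rests on a few compounds, and the source may have more. Where it says the series, first, only, none or still open, it means among the compounds named here.

Compound 1 `Cc1c(-c2ccccc2)sc(N)c1C(=O)c1ccc(Cl)cc1` gives 1% in an assay on CHO cells for displacement of a labelled ligand from adenosine receptor A3 (Homo sapiens), read by scintillation counting, tested at 10 uM; on this read-out higher numbers stand for more inhibition at the one concentration tested (going by the name of the read-out) and lower numbers for less inhibition; compound 2 `Cc1sc(N)c(C(=O)c2ccc(Cl)cc2)c1-c1ccccc1` gives 1% in this assay. Compound 3 `CC(C)(C)Cc1c(-c2cccc(F)c2F)sc(N)c1C(=O)c1ccc(Cl)cc1` gives 1% in this assay, level with compounds 1 and 2 at the digits shown; its nearest neighbour is compound 1 and its furthest compound 2, both without change beyond the scatter. Compound 4 `CC(C)(C)Cc1c(-c2cccs2)sc(N)c1C(=O)c1ccc(Cl)cc1` differs from compound 3 in one place: thiophen-2-yl in place of 2,3-difluorophenyl on an aromatic carbon. For the measured compounds named here, no step between measured compounds exists in this set, so no size of change for an aryl swap is known from the data. Given that compound 3 stands at 1%, compound 4 is expected to show a step of no change at the digits printed from compound 3 to compound 4 (within the scatter), that is none beyond the scatter. Compound 4 is therefore estimated at 1%, within -5% to 10%.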

Compound 4, a percentage reported as inhibition, at one concentration (the size of the read-out at that concentration, not a potency): 1%
For compound 4 middle estimate and measured number coincide at the digits printed; the range from low to high includes it.
By their numbers in this assay, from the lowest: compounds 1, 2, 3 and 4 (each within the scatter of the next).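

In this assay, for the compounds shown here, the swap of 2,3-difluorophenyl for thiophen-2-yl, on the aromatic carbon next to the ring sulfur, gives the first readable step at this position, no change at the digits printed from compound 3 to compound 4 (within the scatter). At this position, then, a five-membered aromatic ring with 1 sulfur reads the same as a six-membered aromatic ring of carbon only, in this one pair. Nothing measured accounts for this result.

Going by these compounds, whether a carboxylic acid or an aminomethyl group at this position would move the reading remains open. So does the effect of a longer chain in place of the neopentyl group.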